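Swapping a pentyl chain for a fluorinated phenyl ring

The compounds below may be only part of what the source reports. "The series", "measured", "known", "first", "only" and "open" are said of these compounds alone.

Compound 2 `CCCCCc1cn(C(c2ccccc2)c2cc3cc(Br)ccc3nc2OC)nn1` was tested in an ADME assay on HEK293 cells (Homo sapiens) for cytotoxicity, read by sulforhodamine B assay, with a stated time of 48 h, tested at 10 uM (on this read-out lower numbers stand for less inhibition and higher numbers for more inhibition at the one concentration tested (going by the name of the read-out)), where compound 2 gave -2%. Among the measured compounds shown here, its only measured relative is compound 1 `COc1nc2ccc(Br)cc2cc1C(c1ccccc1)n1cc(-c2ccc(Br)cc2)nn1`, which in this assay gave 6.28%. Compound 2 sits lowest of these two numbers, and the step of a number 8.3 percentage points lower from compound 1 to compound 2 (within the scatter) lies within the usual scatter, so the two compounds cannot be told apart on this read-out. The next compound, compound 3 `COc1nc2ccc(Br)cc2cc1C(c1ccccc1)n1cc(-c2ccc(F)cc2)nn1`, differs from compound 2 in one place: 4-fluorophenyl in place of pentyl on an aromatic carbon. This change runs in the opposite sense to the step from compound 1 to compound 2, putting an aromatic ring back where the chain had been, with fluorine in place of bromine. Since that earlier step stayed within the scatter, no step beyond the scatter is expected here either; the expected step of a number 6 percentage points higher from compound 2 to compound 3 (within the scatter) is small. Compound 3 is therefore estimated to give 4% in this assay, within a range from -8% to 18%.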

Compound 3, a percentage reported as inhibition, at one concentration (the size of the read-out at that concentration, not a potency): 4.04%
For compound 3 the middle estimate is 0 percentage points below the measured one; the range from low to high includes it.
By their numbers in this assay, from the lowest: compounds 2, 3 and 1 (each within the scatter of the next).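

Three groups can now be compared on this aromatic carbon of the five-membered ring in this assay, and none stands apart: 4-fluorophenyl in place of pentyl gives a number 6 percentage points higher from compound 2 to compound 3 (within the scatter), so an aromatic ring and a straight chain cannot be told apart here. The new compound also tests the substituent on that phenyl ring, a change the earlier pair did not isolate, and fluoro in place of bromo on an aromatic carbon gives a number 2.2 percentage points lower from compound 1 to compound 3 (within the scatter), which again separates nothing. No measurement shown accounts for these small steps. On these data alone, whether an amine, a carboxylic acid or a longer chain at this aromatic carbon would move the number beyond the scatter stays open. So does the behaviour of these compounds at any concentration other than the single one tested.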